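Replacing the piperidine tail in a methyl-bearing analogue

The source may report more compounds than this note shows. Statements on the series, on what has been measured and on what is new or still open speak of the compounds shown alone.

Measured compounds:
compound 1 `COc1cc2c(Oc3ccc(NC(=O)c4nn(-c5ccccc5)c(=O)cc4C)cc3F)ccnc2cc1OCCCN1CCCCC1`: 160 nM
compound 2 `Cc1cc(=O)n(-c2ccccc2)nc1C(=O)Nc1ccc(Oc2ccnc3cc(OCCCN4CCC(C)CC4)ccc23)c(F)c1`: 120 nM
compound 3 `COc1cc2c(Oc3ccc(NC(=O)c4nn(-c5ccccc5C)c(=O)cc4C)cc3F)ccnc2cc1OCCCN1CCCCC1`: 1310 nM

In a functional assay on MKN-45 cells (Homo sapiens) for inhibition, read by MTT assay, with a stated time of 72 h (on this read-out higher numbers stand for weaker inhibition and lower numbers for stronger inhibition), compound 3 gives the highest number of the three: compound 1 sits lower by an 8.2-fold higher number from compound 1 to compound 3 (0.91 log units; beyond the scatter), and compound 2 lies lower still, a gap beyond the scatter. For the measured compounds named here, the only single-point step among the measured compounds is that one, methyl in place of hydrogen on an aromatic carbon, which raised the number modestly.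

Compound 4 `COc1cc2c(Oc3ccc(NC(=O)c4nn(-c5ccccc5C)c(=O)cc4C)cc3F)ccnc2cc1OCCCN1CCN(C)CC1` differs from compound 3 in one place: 4-methylpiperazin-1-yl in place of piperidin-1-yl on a saturated chain carbon, three bonds along the chain from an oxygen on an aromatic ring. Going by the values given here, no measured pair isolates this change. Compound 2 carries a different saturated amine on the same kind of chain, but it also lacks a methoxy group relative to compound 1, so its value cannot be attributed to the amine alone. With nothing in the data that speaks to swapping the terminal ring, the expectation for compound 4 in this assay is that it stays close to compound 3, with no step beyond the scatter in either direction, an estimated step of a 1.0-fold lower number from compound 3 to compound 4 (0.00 log units; within the scatter). Compound 4 is therefore estimated at 1300 nM, with a range from 500 nM to 3500 nM.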

Compound 4, half-maximal inhibitory concentration: 1630 nM
Beside the measured number, compound 4's estimate is 1.3-fold (0.10 log units) below it; measured number inside the range.
By their numbers in this assay, from the lowest: compounds 2 and 1 (each within the scatter of the next); then compounds 3 and 4 (each within the scatter of the next).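

In this assay, for the compounds shown here, the step in the terminal ring gives a 1.2-fold higher number from compound 3 to compound 4 (0.09 log units; within the scatter) and is the first reading that isolates a change at this place, on a saturated chain carbon, three bonds along the chain from an oxygen on an aromatic ring. It shows that, on the methyl-bearing background of compound 3, 4-methylpiperazin-1-yl and piperidin-1-yl cannot be told apart in these cells, even though a ring with 2 hetero atoms enters where a ring with 1 hetero atom leaves. Of the two single-place changes now shown, only the methyl change gives a step beyond the scatter, and no measurement at hand explains why the ring swap leaves the reading within it.

From the compounds shown here alone, whether the same swap would read alike on compound 1, which lacks that methyl, stays open, since this one pair speaks only for the background of compound 3. Also open, going by these compounds, is whether the tolerance extends to other chain ends such as a morpholine or a dimethylamino group, or to a longer chain carrying the same rings.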